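Naphthyl attachment point: compound 1 to compound 4

The compounds below may be only part of what the source reports. "The series", "measured", "known", "first", "only" and "open" are said of these compounds alone.

Measured in a functional assay on MDA-MB-231 cells (Homo sapiens) for antiproliferative activity, with a stated time of 5 days; on this read-out lower numbers stand for stronger inhibition and higher numbers for weaker inhibition:
compound 1 `CC1OC2(C=CC(=O)C=C2)N(c2nc(-c3cccc4ccccc34)nn2-c2ccccc2)C1=O` gives 100 nM
compound 2 `O=C1C=CC2(C=C1)OCC(=O)N2c1nc(-c2cccc3ccccc23)nn1-c1ccccc1` gives 50 nM
compound 3 `O=C1C=CC2(C=C1)OCC(=O)N2c1nc(-c2ccc3ncccc3c2)nn1-c1ccccc1` gives 50 nM
compound 4 `CC1OC2(C=CC(=O)C=C2)N(c2nc(-c3ccc4ccccc4c3)nn2-c2ccccc2)C1=O` is not yet measured

Compound 1 holds the highest of the three numbers, but its standing is thin: the step of a 2.0-fold lower number from compound 1 to compound 2 (0.30 log units; within the scatter) is within the scatter, and the number for compound 3 sits at the same distance from compound 1 as that of compound 2, so no order among the three can be claimed.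

Compound 4 differs from compound 1 by naphthalen-2-yl in place of naphthalen-1-yl on an aromatic carbon.

Among the measured compounds shown here, no measured step tests this swap directly. For the measured compounds named here, the only step in which the aryl group on the five-membered ring is exchanged, no change at the digits printed from compound 2 to compound 3 (within the scatter), stayed within the scatter, and the one other step in the set, a 2.0-fold lower number from compound 1 to compound 2 (0.30 log units; within the scatter), did likewise. On that basis a step of no change at the digits printed from compound 1 to compound 4 (within the scatter) is expected, that is, none beyond the scatter. Compound 4 is therefore estimated at 100 nM in this assay, with a range from 40 nM to 250 nM.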

Compound 4, half-maximal inhibitory concentration: 70 nM
Estimate against measurement, compound 4: 1.4-fold (0.15 log units) above; measured number inside the range.
By their numbers in this assay, from the lowest: compounds 2, 3, 4 and 1 (each within the scatter of the next).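

In this assay, naphthalen-2-yl in place of naphthalen-1-yl gives a 1.4-fold lower number from compound 1 to compound 4 (0.15 log units; within the scatter), so moving only the attachment point of the naphthalene on this aromatic carbon leaves the result within the scatter. The earlier exchange at this carbon, from naphthalen-1-yl to quinolin-6-yl, changed the atoms of the group as well as its attachment point, whereas this pair has the same atoms joined differently and so isolates the attachment point. No evidence here accounts for this result.

Open, as far as these compounds go, is whether a group of another kind on this carbon, such as a carboxylic acid, a dimethylamino group or a plain methyl, would give a step beyond the scatter. Also open, from the compounds shown here alone, is how naphthalen-2-yl reads on the core of compound 2, which lacks the methyl on the saturated ring carbon.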